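A few compounds are considered here, and "the series" means these few. Any claim that something is new, unique, unknown or untested is made for them only; others in the source may bear on it.

Of the compounds shown here, three with the same core have been measured in an assay on HeLa cells for displacement of a labelled ligand from 5-hydroxytryptamine receptor 6 (Homo sapiens); on this read-out lower numbers stand for stronger inhibition and higher numbers for weaker inhibition. Compound 1, `O=S(=O)(c1cccc(Cl)c1)c1cccc2oc(N3CCNCC3)nc12`, gives 31 nM. Compound 2, `O=S(=O)(c1ccc2oc(N3CCNCC3)nc2c1)c1cccc2ccccc12`, gives 52 nM. Compound 3, `CN1CCN(c2nc3c(S(=O)(=O)c4cccc5ccccc45)cccc3o2)CC1`, gives 9.7 nM, the lowest of the three numbers; its gap to compound 1 and its larger gap to compound 2 both lie beyond the usual scatter of this assay, so compound 3 stands as the most potent of the measured set.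

The next compound, compound 4, `O=S(=O)(c1cccc2ccccc12)c1cccc2oc(N3CCN(C4CCCC4)CC3)nc12`, has not yet been measured in this assay. It differs from compound 3 in one place: cyclopentyl in place of methyl on an amine nitrogen in a ring. For the measured compounds named here, no measured pair here shows what such a change does, so the expectation rests on compound 3 alone. A small loss of potency, of a size near the edge of the scatter, is expected rather than a gain, since the larger group replaces the methyl that went with the best number, 9.7 nM, of compound 3. The expected step is a 2.6-fold higher number from compound 3 to compound 4 (0.41 log units; beyond the scatter). Compound 4 is therefore estimated at 25 nM, within a range from 6 nM to 100 nM.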

Compound 4, inhibition constant: 79 nM
For compound 4 the middle estimate is 3.2-fold (0.50 log units) below the measured one; the range from low to high includes it.
By their numbers in this assay, from the lowest: compound 3; then compounds 1, 2 and 4 (each within the scatter of the next, the first and the last beyond it).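

For the compounds shown here, this is the first pair in the set that differs in one place, and it shows that the amine nitrogen in the ring is sensitive to what it carries: in this assay, cyclopentyl in place of methyl gives an 8.1-fold higher number from compound 3 to compound 4 (0.91 log units; beyond the scatter) on this read-out. The larger group costs potency, yet compound 4 still gives 79 nM, so the position tolerates a five-membered carbon ring without activity disappearing. No supporting data here bear on why the step has this size. 

One pair cannot tell whether the loss follows the size of the group or comes with the ring itself. An ethyl or isopropyl group on this nitrogen, or a plain hydrogen with the rest of compound 3 kept, would help separate those two readings.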